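Swapping the aryl group on the saturated ring carbon

The compounds below may be only part of what the source reports. "The series", "measured", "known", "first", "only" and "open" are said of these compounds alone.

Of the compounds shown here, two of a shared core have been measured. Compound 1 `COc1cc(C2=NN(C(C)=O)C(c3ccc(Cl)c(Cl)c3)O2)cc(OC)c1OC` gives 3.1% in a functional assay on BGC-823 cells (Homo sapiens) for antiproliferative activity, read by MTT assay, tested at 5 uM; on this read-out lower numbers stand for a weaker effect and higher numbers for a stronger effect at the one concentration tested. Compound 2 `COc1cc(C2=NN(C(C)=O)C(c3ccc(C(F)(F)F)cc3)O2)cc(OC)c1OC` gives 3.4% in this assay, and it stands within the scatter of compound 1, the only other number shown, since the step of a number 0.3 percentage points higher from compound 1 to compound 2 (within the scatter). Compound 3 `COc1cc(C2=NN(C(C)=O)C(c3ccccc3F)O2)cc(OC)c1OC` is not yet measured; it differs from compound 2 in one place: 2-fluorophenyl in place of 4-(trifluoromethyl)phenyl on a saturated ring carbon. Going by the values given here, the only measured step, from compound 1 to compound 2, also swapped the group on this saturated ring carbon and stayed within the scatter, so no change beyond the scatter is expected from the step of a number 0.1 percentage points higher from compound 2 to compound 3 (within the scatter). Among the compounds with values here, with only two numbers, both small, a wider range is kept open. Compound 3 is therefore estimated at 3.5% in this assay, between 0% and 12%.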

Compound 3, a percentage reported as inhibition, at one concentration (the size of the read-out at that concentration, not a potency): 32.8%
The estimate for compound 3 lay 29.3 percentage points below the measured number, outside the stated range (above it).
By their numbers in this assay, from the lowest: compounds 1 and 2 (each within the scatter of the next); then compound 3.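

In this assay, the group on this saturated ring carbon proves able to change the read-out, as shown by the step of a number 29.4 percentage points higher from compound 2 to compound 3 (beyond the scatter) and the step of a number 29.7 percentage points higher from compound 1 to compound 3 (beyond the scatter). Going by these compounds alone, the only earlier step, between 3,4-dichlorophenyl and 4-(trifluoromethyl)phenyl, had suggested no such sensitivity, whereas 2-fluorophenyl now stands apart from both groups. Each new step changes both the substituent on the phenyl ring and where it sits, so these compounds cannot separate those two changes.

No measurement shown here explains the rise. From the compounds shown here alone, it remains open whether the gain belongs to fluorine or to its placement in 2-fluorophenyl, which 4-fluorophenyl, 2-chlorophenyl or an unsubstituted phenyl group could help to settle.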